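From pyridin-3-yl to pyridin-4-yl in compound 4

This account rests on a few compounds, and the source may have more. Where it says the series, first, only, none or still open, it means among the compounds named here.

Measured in a functional assay for inhibition, with Homo sapiens as the target; a higher number here means a weaker inhibitor, a lower number a stronger inhibitor:
- compound 1 `Oc1ccc(Nc2nccc(-c3ccncc3)n2)cc1` gives 3300 nM
- compound 2 `COc1ccc(Nc2nccc(-c3ccncc3)n2)cc1` gives 4200 nM
- compound 3 `CN(C)c1ccc(Nc2nccc(-c3cccnc3)n2)cc1` gives 2800 nM

Compound 3 sits within the scatter of both compound 1 and compound 2, so the three values form one group. Compound 4 `CN(C)c1ccc(Nc2nccc(-c3ccncc3)n2)cc1` differs from compound 3 by a single exchange (pyridin-4-yl in place of pyridin-3-yl on an aromatic carbon), pyridin-4-yl in place of pyridin-3-yl on an aromatic carbon. Among the compounds with values here, this exchange has no measured step of its own. Within the data shown here, the only measured step, a 1.3-fold higher number from compound 1 to compound 2 (0.10 log units; within the scatter), is a different change, methyl in place of hydrogen on an oxygen on an aromatic ring. Compound 1 and compound 2 already carry pyridin-4-yl, and their values lie within the scatter of compound 3. The expected step in this assay is a 1.2-fold higher number from compound 3 to compound 4 (0.07 log units; within the scatter), with no change expected beyond the scatter. For compound 4 the estimated value is 3300 nM, with an expected range from 1500 nM to 7000 nM.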

Compound 4, half-maximal inhibitory concentration: 3700 nM
The estimate for compound 4 lay 1.1-fold (0.05 log units) below the measured number; the range from low to high includes it.
By their numbers in this assay, from the lowest: compounds 3, 1, 4 and 2 (each within the scatter of the next).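

In this assay, pyridin-4-yl and pyridin-3-yl on this aromatic carbon cannot be told apart (a 1.3-fold higher number from compound 3 to compound 4 (0.12 log units; within the scatter)), so the position of the pyridine nitrogen shows no effect beyond the scatter with dimethylamino in place. With pyridin-4-yl held fixed, dimethylamino also cannot be told apart from methoxy (a 1.1-fold lower number from compound 2 to compound 4 (0.06 log units; within the scatter)) or hydroxy (a 1.1-fold higher number from compound 1 to compound 4 (0.05 log units; within the scatter)). No measurement here gives a cause for these results.

Open, from the compounds shown here alone, is whether replacing the pyridine with phenyl would shift the value beyond the scatter. The same applies to replacing dimethylamino with morpholine or a carboxylic acid.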